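A few compounds are considered here, and "the series" means these few. Any claim that something is new, unique, unknown or untested is made for them only; others in the source may bear on it.

In a functional assay on the whole organism with Rattus norvegicus as the target (a lower number here means that less compound is needed, a higher number that more compound is needed for the effect), compound 1 `CCOC(=O)C(=O)Nc1nc(-c2ccc(F)cc2)cs1` gives > 10 mg/kg, which is a limit and not a number. Compound 2 `CCOC(=O)C(=O)Nc1nc(-c2ccc([N+](=O)[O-])cc2)cs1` also stands only at a limit, > 100 mg/kg. Compound 3 `CCOC(=O)C(=O)Nc1nc(-c2ccc(NC(=O)C(F)(F)F)cc2)cs1` has ((trifluoromethyl)carbonyl)amino in place of nitro on an aromatic carbon. Within the data shown here, the only measured change on that aromatic carbon is a step that the two limits leave unreadable from compound 1 to compound 2, and it gives neither a size nor a direction to build on. Among the measured compounds shown here, no step of definite size or direction can therefore be expected with confidence, and the estimated at least 2.0-fold lower number from compound 2 to compound 3 (0.30 log units; that floor lies within the scatter) is only tentative. Compound 3 is expected near 50 mg/kg, with an estimated range of 5 mg/kg to 200 mg/kg.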

Compound 3, dose for half-maximal effect: about 1 mg/kg
Estimate against measurement, compound 3: 50-fold (1.70 log units) above, outside the stated range (below it).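

On this aromatic carbon, para to a large group, the choice of group clearly matters in this assay: ((trifluoromethyl)carbonyl)amino gives an at least 100-fold lower number from compound 2 to compound 3 (2.00 log units; beyond the scatter) and an at least 10-fold lower number from compound 1 to compound 3 (1.00 log units; beyond the scatter). Among these compounds, compound 3 is the first compound here with a readable value rather than a limit. Both steps are only minimum sizes, because each starts from a limit: the limit of > 10 mg/kg in this assay, at which 1 of the 3 values shown sits.

Going by these compounds, the second step has the same kind of start: the limit of > 100 mg/kg in this assay, at which 1 of the 3 values shown sits. Whether the trifluoromethyl part or the amide link matters more stays open, and a plain amine or an acetylamino group on this carbon would separate the two.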